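A few compounds are considered here, and "the series" means these few. Any claim that something is new, unique, unknown or untested is made for them only; others in the source may bear on it.

Measured compounds:
- compound 1, `c1ccc(Cn2cc(-c3ccccc3)c3c2CCNC3)cc1`: 220 nM
- compound 2, `Cc1ccc(-c2cn(Cc3ccccc3)c3c2CNCC3)cc1`: 35 nM

Both compounds were tested in an assay on HEK293 cells for displacement of a labelled ligand from 5-hydroxytryptamine receptor 7 (Rattus norvegicus), with a stated time of 60 min; on this read-out lower numbers stand for stronger inhibition and higher numbers for weaker inhibition. Compound 2 shows the lowest number of the two, and its nearest neighbour is compound 1, from which it is separated by a 6.3-fold lower number from compound 1 to compound 2 (0.80 log units; beyond the scatter). That single step is the only one so far. The structural change between the two is methyl in place of hydrogen on an aromatic carbon.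

Compound 3, `CC(C)(C)c1ccc(-c2cn(Cc3ccccc3)c3c2CNCC3)cc1`, is not yet measured. It differs from compound 2 by tert-butyl in place of methyl on an aromatic carbon of a six-membered aromatic ring of carbon only, para to a large group. The step from compound 1 to compound 2 bears on this change, since it enlarged the group at the same place, and it gave a modest gain. Whether a further enlargement continues that trend cannot be told from two compounds; the expectation for this assay is therefore a step of a 1.4-fold higher number from compound 2 to compound 3 (0.15 log units; within the scatter), which lies within the scatter. Compound 3 is estimated at 50 nM, with a range from 10 nM to 250 nM.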

Compound 3, inhibition constant: 10000 nM
Compound 3: the middle estimate sits 200-fold (2.30 log units) below what was measured; the measured number lies above the stated range.
By their numbers in this assay, from the lowest: compound 2; then compound 1; then compound 3.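

In this assay this aromatic carbon, para to a large group, does not reward ever larger alkyl groups: exchanging methyl for tert-butyl, which brings the group from 1 heavy atom to 4, gives a 290-fold higher number from compound 2 to compound 3 (2.46 log units; beyond the scatter) and so reverses the modest gain that methyl brought over hydrogen. The loss also goes well past the starting point, since the comparison with hydrogen at the same place gives a 45-fold higher number from compound 1 to compound 3 (1.66 log units; beyond the scatter) and makes compound 3 the weakest of the three by numbers that lie beyond the scatter. Nothing available explains why this one change costs so much, so the result records the size of the drop and not its cause.

The compounds shown leave open where between methyl and tert-butyl the drop sets in, a question that ethyl or isopropyl at this place would help to answer. They also leave open whether the drop is specific to branched alkyl groups, which a compound carrying methoxy, chlorine or an amine at the same carbon could begin to test.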